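A few compounds are considered here, and "the series" means these few. Any claim that something is new, unique, unknown or untested is made for them only; others in the source may bear on it.

Within the data shown here, compound 1, with the structure `Cc1c(Nc2nc(N)c3c(C#N)c(N4CCC[C@H]4C)n(C)c3n2)cnn1[C@H]1CCOC1`, is one of two compounds so far measured in an assay on HEK293 cells for inhibition of Leucine-rich repeat serine/threonine-protein kinase 2 (Homo sapiens), with a stated time of 48 h; a higher number here means a weaker inhibitor, a lower number a stronger inhibitor; there compound 1 gives 140 nM, the lowest of the two numbers. The other, compound 2, with the structure `C[C@@H]1CCCN1c1c(C#N)c2c(N)nc(Nc3cn(C)nc3Cl)nc2n1C`, gives 190 nM in this assay, and the gap between the two lies within the usual scatter, so the two numbers count as the same. Compound 3, with the structure `Cc1c(Nc2nc(N)c3c(C#N)c(N4CCC[C@H]4C)n(C)c3n2)cnn1[C@@H]1CCOC1`, has not yet been measured. It differs from compound 1 as follows: the two compounds have the same atoms and bonds and differ only in configuration as drawn: 1 of 2 stereo elements differ; a stereocentre at a saturated ring carbon is drawn S in compound 1 and R in compound 3. Among the measured compounds shown here, no pair of measured compounds differs in this way, so the measurements give no guide to what the change does. A flipped stereocentre can move a number in either direction, and a step within the scatter is as plausible as a larger one. Compound 3 is therefore expected to land with a step of a 1.6-fold higher number from compound 1 to compound 3 (0.20 log units; within the scatter), a small move toward a higher number. Compound 3 is estimated at 220 nM, with a range from 70 nM to 700 nM.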

Compound 3, half-maximal inhibitory concentration: 180 nM
Compound 3: middle estimate off by 1.2-fold (0.09 log units), on the high side; the range from low to high includes it.
By their numbers in this assay, from the lowest: compounds 1, 3 and 2 (each within the scatter of the next).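

This is the first pair shown that differs in one place only, and that place is a stereocentre at a saturated ring carbon, drawn S in compound 1 and R in compound 3. In this assay, flipping it gives a 1.3-fold higher number from compound 1 to compound 3 (0.11 log units; within the scatter), so the two numbers count as the same and neither configuration at this carbon stands out. Among these compounds, the comparison is a clean one, since only one thing separates the pair: the fact that compounds 1 and 3 differ only in the configuration as drawn.

The compounds shown leave open whether flipping the second stereo element, which is the same in both compounds, would also leave the number within the scatter. They also leave open whether replacing this saturated ring with an amine or a longer chain would move the number beyond the scatter.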